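The compounds below may be only part of what the source reports. "The series", "measured", "known", "first", "only" and "open" are said of these compounds alone.

Measured in a functional assay on MT4 cells (Homo sapiens) for cytotoxicity, read by MTT assay; a higher number here means that more compound is tolerated, a lower number that less compound is tolerated:

- compound 1 `Cc1c(O)nc(Sc2ccccc2)nc1Cc1c(F)cccc1F` gives > 72700 nM (a limit)
- compound 2 `COc1ccc(Sc2nc(O)c(C)c(Cc3c(F)cccc3F)n2)cc1` gives 57500 nM
- compound 3 `COc1ccc(Sc2nc(O)c(C)c(Cc3c(Cl)cccc3Cl)n2)cc1` gives > 61400 nM (a limit)

Compound 3 has only a limit, > 61400 nM, and no exact number. Compound 4 `Cc1c(O)nc(Sc2ccccc2)nc1Cc1c(Cl)cccc1Cl` has not yet been measured. It carries hydrogen in place of methoxy on an aromatic carbon, (hydrogen in place of methoxy on an aromatic carbon). The closest evidence is the same exchange in reverse, methoxy in place of hydrogen, seen in an at least 1.2-fold lower number from compound 1 to compound 2 (0.10 log units; that floor lies within the scatter). The change of 2,6-difluorophenyl to 2,6-dichlorophenyl, seen in an at least 1.0-fold higher number from compound 2 to compound 3 (0.02 log units; that floor lies within the scatter), also stays within the scatter. No step beyond the scatter is therefore expected, and the estimated change is a step that the limit leaves unreadable from compound 3 to compound 4. For compound 4 the expected value is 66000 nM, within an estimated range from 35000 nM to 90000 nM.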

Compound 4, half-maximal cytotoxic concentration: > 66300 nM
Compound 4: only a limit was reported (the forecaster's own chance of this, stated with the estimate: 70%); middle value at least 1.0-fold (0.00 log units) away from the limit.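

The steps from compound 3 to compound 4 and from compound 1 to compound 4 cannot be read, as each joins two limits. The compounds shown leave open how far compound 1, compound 3 and compound 4 actually differ in this assay.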